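Moving the trifluoromethyl on the hydrazone aryl of compound 3

The source may report more compounds than this note shows. Statements on the series, on what has been measured and on what is new or still open speak of the compounds shown alone.

Compound 3 `CN(C(=O)NC(=O)c1ccc(C(F)(F)F)cc1)c1nc(C(F)(F)F)c(C(=O)N/N=C/c2ccc(C(F)(F)F)cc2)s1` gives in a functional assay on A549 cells (Homo sapiens) for inhibition, read by MTT assay, with a stated time of 72 h (on this read-out higher numbers stand for weaker inhibition and lower numbers for stronger inhibition), only a limit, > 100 ug/mL; this is the limit of the assay and not a number (the limit of > 100 ug/mL in this assay, at which 1 of the 3 values shown sits). The two compounds that carry a number share the 3-(trifluoromethyl)phenyl hydrazone arm but differ from compound 3 at the acyl group: compound 1 `CN(C(=O)NC(=O)c1ccc(Cl)cc1Cl)c1nc(C(F)(F)F)c(C(=O)N/N=C/c2cccc(C(F)(F)F)c2)s1` gives in this assay 10.6 ug/mL and compound 2 `CN(C(=O)NC(=O)c1c(F)cccc1F)c1nc(C(F)(F)F)c(C(=O)N/N=C/c2cccc(C(F)(F)F)c2)s1` gives 27.6 ug/mL. Among the compounds with values here, the only measured step, a 2.6-fold higher number from compound 1 to compound 2 (0.42 log units; beyond the scatter), concerns the acyl group alone and so does not bear on the change at hand. Compound 4 `CN(C(=O)NC(=O)c1ccc(C(F)(F)F)cc1)c1nc(C(F)(F)F)c(C(=O)N/N=C/c2cccc(C(F)(F)F)c2)s1` differs from compound 3 by 3-(trifluoromethyl)phenyl in place of 4-(trifluoromethyl)phenyl on a carbon with a double bond to nitrogen. Within the data shown here, no measured pair isolates this change, so the expectation rests on compounds 1 and 2, which carry the same hydrazone arm as compound 4, and on compound 3, which shares its acyl group and sits at the limit. Compound 4 is therefore expected to land between those cases, an estimated step of an at least 1.8-fold lower number from compound 3 to compound 4 (0.25 log units; that floor lies within the scatter), giving an estimate of 55 ug/mL with a range from 15 ug/mL to 150 ug/mL.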

Compound 4, half-maximal inhibitory concentration: 6.66 ug/mL
For compound 4 the middle estimate is 8.3-fold (0.92 log units) above the measured one; the measured number lies below the stated range.
By their numbers in this assay, from the lowest: compounds 4 and 1 (each within the scatter of the next); then compound 2. At a limit, above all of these: compound 3.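

In this assay compound 3 gives > 100 ug/mL, which is a limit of the assay and not a number. Within the data shown here, with the acyl group held constant, 3-(trifluoromethyl)phenyl in place of 4-(trifluoromethyl)phenyl gives an at least 15-fold lower number from compound 3 to compound 4 (1.17 log units; beyond the scatter), the first reading of this change on its own, and it takes the series from a limit to a measured value. With the 3-(trifluoromethyl)phenyl arm held constant, the acyl group of compound 3 shows a 4.1-fold lower number from compound 2 to compound 4 (0.62 log units; beyond the scatter) and a 1.6-fold lower number from compound 1 to compound 4 (0.20 log units; within the scatter), so this group also sits among the measured values.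

Going by these compounds, it remains open whether the same change would carry over to the 2,4-dichlorophenyl and 2,6-difluorophenyl acyl groups, and the full size of the step remains unknown. Also open, on these data alone, is how a chlorine, a methoxy group or an amine in place of the trifluoromethyl on this aryl ring would read in this assay.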